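Methylamino to ethylamino on the shared core

The compounds below may be only part of what the source reports. "The series", "measured", "known", "first", "only" and "open" are said of these compounds alone.

Measured so far in a functional assay on MCF7 cells (Homo sapiens) for antiproliferative activity, read by MTT assay, with a stated time of 48 h; a lower number here means a stronger inhibitor, a higher number a weaker inhibitor
- compound 1 `C=C(c1ccc(OC)cc1NC(=O)CO)c1ccc(OC)c2c1C=CC(C)(C)O2` gives 590 nM
- compound 2 `C=C(c1ccc(OC)cc1NC(=O)CNC)c1ccc(OC)c2c1C=CC(C)(C)O2` gives 1010 nM

Compound 2 has a single measured neighbour, and the two values lie within the scatter of each other, so neither can be ranked above the other. The next compound to be read is compound 3 `C=C(c1ccc(OC)cc1NC(=O)CNCC)c1ccc(OC)c2c1C=CC(C)(C)O2`, which carries ethylamino where compound 2 carries methylamino. The difference is methyl in place of hydrogen on a saturated chain carbon bound to an amine nitrogen and amounts to methyl in place of hydrogen on a saturated chain carbon bound to an amine nitrogen.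

For the measured compounds named here, no measured step covers this change directly. Going by the values given here, the only step that bears on it puts methylamino in place of hydroxy on the same side chain, and it reads a 1.7-fold higher number from compound 1 to compound 2 (0.23 log units; within the scatter) as its size. Among the compounds with values here, with that one small step as the sole guide, the data support no direction and no step beyond the scatter is expected in this assay for the new change.

The estimated value for compound 3 is 1100 nM within an expected range of 500 nM to 2400 nM as its two ends. The expected step is a 1.1-fold higher number from compound 2 to compound 3 (0.04 log units; within the scatter) and no more than that.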

Compound 3, half-maximal inhibitory concentration: 2920 nM
The estimate for compound 3 lay 2.7-fold (0.42 log units) below the measured number; the whole stated range lies below it.
By their numbers in this assay, from the lowest: compounds 1 and 2 (each within the scatter of the next); then compound 3.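

In this assay this position on the side chain responds to a small change: methyl in place of hydrogen on a saturated chain carbon bound to an amine nitrogen gives a 2.9-fold higher number from compound 2 to compound 3 (0.46 log units; beyond the scatter), whereas the exchange of hydroxy for methylamino gave only a 1.7-fold higher number from compound 1 to compound 2 (0.23 log units; within the scatter). The exchange of hydroxy for ethylamino gives a 4.9-fold higher number from compound 1 to compound 3 (0.69 log units; beyond the scatter), so compound 3 is the weakest of the three, with both of its steps beyond the scatter, while compound 1 and compound 2 remain unranked against each other. Nothing available accounts for the size of the methyl step.

On these data alone, a single step between two amines does not establish a trend with chain length, so it remains open whether a longer chain such as propylamino, or a branched one such as isopropylamino, would continue the rise in the number seen with ethylamino. Also open, as far as these compounds go, is where an unsubstituted amino group or a dimethylamino group on the same side chain would fall relative to compound 2 and compound 3.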